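Fluoro to methylsulfanyl on compound 3

The source may hold more compounds than are shown below. What is called first, only, known or untested is meant among the compounds shown, and "the series" means these compounds.

In a functional assay on M14 cells (Homo sapiens) for cytotoxicity (a higher number here means a weaker inhibitor of growth, a lower number a stronger inhibitor of growth), compound 3 `CSc1ccc(C2=C(c3ccc(F)cc3)C(=O)N3CCCC3C2)cc1` gives 600 nM, the lowest number of the three measured. Compound 1 `COc1ccc(C2=C(c3ccc(SC)cc3)CC3CCCN3C2=O)cc1` gives 4000 nM, and compound 2 `CSc1ccc(C2=C(c3ccc(C)cc3)C(=O)N3CCCC3C2)cc1` gives 6000 nM. These two do not separate: a 1.5-fold higher number from compound 1 to compound 2 (0.18 log units; within the scatter).

The next change leads from compound 3 to compound 4 `CSc1ccc(C2=C(c3ccc(SC)cc3)C(=O)N3CCCC3C2)cc1`, with methylsulfanyl in place of fluoro on an aromatic carbon, para to a large group: methylsulfanyl in place of fluoro on an aromatic carbon.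

For the measured compounds named here, two measured steps bear on this change, both ending in fluoro at the same aromatic carbon: a 6.7-fold lower number from compound 1 to compound 3 (0.82 log units; beyond the scatter), and a 10-fold lower number from compound 2 to compound 3 (1.00 log units; beyond the scatter). Read in reverse, each shows fluoro giving way to another group with a rise in the number. Methylsulfanyl itself has not been measured at this carbon, so the comparison rests on methoxy and methyl alone. A rise of similar or somewhat smaller size is therefore expected, with the result likely to land near the values of compound 1 and compound 2 rather than near that of compound 3.

The expected step is a 5.0-fold higher number from compound 3 to compound 4 (0.70 log units; beyond the scatter).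

For compound 4 the estimated value is 3000 nM, with an expected range of 800 nM to 10000 nM.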

Compound 4, concentration for 50% growth inhibition: 5000 nM
Compound 4: middle estimate off by 1.7-fold (0.22 log units), on the low side; low and high end bracket the measured number.
By their numbers in this assay, from the lowest: compound 3; then compounds 1, 4 and 2 (each within the scatter of the next).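

In this assay, methylsulfanyl joins methoxy and methyl as a third group at this carbon that gives a clearly higher number than fluoro, with an 8.3-fold higher number from compound 3 to compound 4 (0.92 log units; beyond the scatter). Against the two non-fluoro compounds, the change reads a 1.2-fold lower number from compound 2 to compound 4 (0.08 log units; within the scatter) and a 1.3-fold higher number from compound 1 to compound 4 (0.10 log units; within the scatter), so methylsulfanyl, methyl and methoxy do not separate here, and among these four compounds only the fluoro compound 3 stands apart. No measurement available here accounts for this separation of fluoro from the other three groups.

These compounds leave open whether the low number is particular to fluoro or extends to other groups at this carbon, such as chloro, a nitrile, an amine or a carboxylic acid, or to plain hydrogen. They also leave open what happens at the methylsulfanyl on the other aromatic ring, which stays the same across all four compounds, so the series says nothing yet about a chloro or a hydroxyl group there, or about whether fluoro would give a similar result at that place.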